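A few compounds are considered here, and "the series" means these few. Any claim that something is new, unique, unknown or untested is made for them only; others in the source may bear on it.

Measured in a functional assay on HEK293 cells for antagonist activity at metabotropic glutamate receptor 5 (Rattus norvegicus), read by calcium flux; on this read-out higher numbers stand for weaker inhibition and lower numbers for stronger inhibition:
Compound 1 `Brc1cccc(Nc2ncnc3ccc(Br)cc23)c1` gives 174 nM.
Compound 2 `CN(c1cccc(Br)c1)c1ncnc2ccc(Cl)cc12` gives only a limit, > 30000 nM.

Compound 2 therefore stands at the limit in this assay (the limit of > 30000 nM in this assay, at which 1 of the 2 values shown sits), with no number behind it. Compound 3 `CN(c1cccc(Br)c1)c1ncnc2ccc(Br)cc12` differs from compound 2 in one place: bromo in place of chloro on an aromatic carbon. Among the measured compounds shown here, no measured pair carries this change, so its size is unknown from the data. For the measured compounds named here, the only anchor is compound 2 sitting at the limit. Compound 3 is expected to stay at or near that limit, with no step beyond the scatter: a step that the limit leaves unreadable from compound 2 to compound 3. Compound 3 is estimated at 40000 nM, range 12000 nM to 120000 nM.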

Compound 3, half-maximal inhibitory concentration: > 30000 nM
Compound 3 gave a limit, no number (the forecaster's own chance of this, stated with the estimate: 80%); the middle value is on the limit's open side.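

In this assay, among the compounds shown here, methyl in place of hydrogen on a nitrogen on an aromatic ring, with bromo unchanged, gives an at least 170-fold higher number from compound 1 to compound 3 (2.23 log units; beyond the scatter); this is the first one-place reading of that change. Compound 3 gives only a limit, > 30000 nM, not a number. The step for bromo in place of chloro on an aromatic carbon cannot be read, and with methyl on the nitrogen both halogens end at the limit: the limit of > 30000 nM in this assay, at which 2 of the 3 values shown sit.

Still open, going by these compounds, is how an ethyl group or a longer chain on that nitrogen would read. Also open, on these data alone, is whether a methoxy group in place of the bromo would lift a methylated compound off the limit.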